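Ethoxy to allyloxy: a small expected step

The compounds below may be only part of what the source reports. "The series", "measured", "known", "first", "only" and "open" are said of these compounds alone.

Compound 1 `O=C1C=C[C@@H](OC2CCCCC2)O[C@@H]1CO`: 13300 nM
Compound 2 `CCO[C@@H]1C=CC(=O)[C@@H](CO)O1`: 3500 nM

Both compounds were measured in a functional assay on HL-60 cells (Homo sapiens) for inhibition, read by MTT assay, with a stated time of 72 h; a lower number here means a stronger inhibitor, a higher number a weaker inhibitor. Compound 2 has the lower number of the two at 3500 nM, and compound 1 lies higher at 13300 nM. The gap between them is beyond the usual scatter, which makes compound 2 the stronger inhibitor of this pair.

Compound 3 `C=CCO[C@@H]1C=CC(=O)[C@@H](CO)O1` is the next compound to be read against compound 2. The structural change is vinyl in place of methyl on a saturated chain carbon bound to an oxygen on a saturated carbon, so that ethoxy becomes allyloxy.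

Within the data shown here, no two measured compounds differ in one place only, so this assay offers no direct precedent for this change. The value of compound 2 at 3500 nM is therefore the only anchor. Given the small size of the change, no step beyond the scatter is expected in this assay, in either direction. The expected change is a 1.2-fold lower number from compound 2 to compound 3 (0.07 log units; within the scatter). Compound 3 is estimated at 3000 nM, with an expected range from 1300 nM to 8000 nM.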

Compound 3, half-maximal inhibitory concentration: 4900 nM
Compound 3: the middle estimate sits 1.6-fold (0.21 log units) below what was measured; the range from low to high includes it.
By their numbers in this assay, from the lowest: compounds 2 and 3 (each within the scatter of the next); then compound 1.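

In this assay, among these compounds, vinyl in place of methyl on a saturated chain carbon bound to an oxygen on a saturated carbon gives a 1.4-fold higher number from compound 2 to compound 3 (0.15 log units; within the scatter), the first step that can be read at a single point of change. The step lies within the scatter, so ethoxy and allyloxy cannot be told apart here: this position accepts the added carbon and the double bond outside aromatic rings without a resolvable shift in the read-out. No supporting measurement accompanies this step, and the data give no account of why the number barely moves.

One small step at one position does not show how far this insensitivity extends, and a longer saturated chain, a benzyl ether or a terminal amine in place of the allyl group would test it more sharply. From the compounds shown here alone, the three compounds also share the rest of the core, so the contribution of the hydroxymethyl and the carbonyl to the read-out remains open.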